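This account rests on a few compounds, and the source may have more. Where it says the series, first, only, none or still open, it means among the compounds named here.

Measured compounds:
- compound 1 `CCN(CC)CCNC(=O)c1ccc(C(CC)(CC)c2ccc(OCC(O)C(C)(C)C)c(C)c2)n1CC`: 490 nM
- compound 2 `CCn1c(C(=O)NCCN)ccc1C(CC)(CC)c1ccc(OCC(O)C(C)(C)C)c(C)c1`: 176 nM
- compound 3 `C#CC(C)OC(=O)c1ccc(C(CC)(CC)c2ccc(OCC(O)C(C)(C)C)c(C)c2)n1CC`: a limit, > 50000 nM

All three share one core and differ only in the group attached to the carbonyl carbon. In a functional assay on HepG2 cells (Homo sapiens), read by MTT assay, with a stated time of 48 h (on this read-out lower numbers stand for stronger inhibition and higher numbers for weaker inhibition), compound 1 gives 490 nM, the highest of the two plain numbers; the nearest is compound 2, and the step of a 2.8-fold lower number from compound 1 to compound 2 (0.44 log units; beyond the scatter) is modest. Compound 3 reaches only a limit of this assay, > 50000 nM, so no number is known for it. The steps of an at least 100-fold higher number from compound 1 to compound 3 (2.00 log units; beyond the scatter) and an at least 280-fold higher number from compound 2 to compound 3 (2.45 log units; beyond the scatter) are both large, and both come from putting an oxygen-linked group in place of a nitrogen-linked one on the carbonyl carbon.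

Compound 4 `CCn1c(C(=O)OCc2ccc(F)cc2)ccc1C(CC)(CC)c1ccc(OCC(O)C(C)(C)C)c(C)c1` is not yet measured. It differs from compound 1 as follows: (4-fluorobenzyl)oxy in place of (2-(diethylamino)ethyl)amino on a carbonyl carbon. This is the same kind of exchange as in compound 3, an oxygen-linked group on the carbonyl carbon, though the entering group is a different one. On that basis a large rise in this assay is expected for compound 4, and it may well give only a limit, as compound 3 does at the limit of > 50000 nM in this assay, at which 1 of the 3 values shown sits. The expected step is a 51-fold higher number from compound 1 to compound 4 (1.71 log units; beyond the scatter), giving an estimate for compound 4 of 25000 nM, within 3000 nM to 200000 nM.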

Compound 4, half-maximal inhibitory concentration: > 50000 nM
Compound 4 gave a limit, no number; the forecaster's own chance of this, stated with the estimate: 55%; middle value at least 2.0-fold (0.30 log units) from the limit.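

With compound 3 alone, the loss of activity could have belonged to the (1-methylprop-2-yn-1-yl)oxy group itself. Compound 4 carries a quite different oxygen-linked group on the carbonyl carbon, (4-fluorobenzyl)oxy with its six-membered aromatic ring, and in this assay the loss appears again, as an at least 100-fold higher number from compound 1 to compound 4 (2.00 log units; beyond the scatter) and as an at least 280-fold higher number from compound 2 to compound 4 (2.45 log units; beyond the scatter) on the carbonyl carbon. Among these four compounds the two nitrogen-linked groups give plain numbers and the two oxygen-linked groups, different as they are, both stop at a limit of the assay rather than a number: the limit of > 50000 nM in this assay, at which 2 of the 4 values shown sit.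

The step between compound 3 and compound 4 cannot be read, so the two oxygen-linked groups cannot be ranked against each other. Both nitrogen-linked groups also carry an amine further along their chain while neither oxygen-linked group does, so the linking atom and that amine change together here, and a group such as (4-fluorobenzyl)amino, linked through nitrogen without a second amine, or an oxygen-linked 2-aminoethyl group would be needed to tell the two apart.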